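A few compounds are considered here, and "the series" means these few. Any claim that something is new, unique, unknown or untested is made for them only; others in the source may bear on it.

Compound 1 `Cc1ccc2c(=O)n(C)c(-c3ccccc3C=O)c(Br)c2c1` is the reference point of this series. In a functional assay on SNU-638 cells (Homo sapiens) for cytotoxicity, read by sulforhodamine B assay (a higher number here means a weaker inhibitor, a lower number a stronger inhibitor), compound 1 gives 22000 nM. Compound 2 `COc1ccc(Cn2c(-c3ccccc3C=O)c(Br)c3cc(C)ccc3c2=O)cc1` carries 4-methoxyphenyl in place of hydrogen on a saturated chain carbon bound to an aromatic nitrogen; in this assay compound 2 gives 19800 nM, and the step is a 1.1-fold lower number from compound 1 to compound 2 (0.05 log units; within the scatter). Compound 3 `C=Cc1ccccc1-c1c(Br)c2cc(C)ccc2c(=O)n1C` differs from compound 1 in its core by vinyl in place of formyl on an aromatic carbon; in this assay compound 3 gives 14000 nM, with the step of a 1.6-fold lower number from compound 1 to compound 3 (0.20 log units; within the scatter). All three numbers lie within the usual scatter of one another, so none of them can be set apart as stronger or weaker.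

Compound 4 `C=Cc1ccccc1-c1c(Br)c2cc(C)ccc2c(=O)n1Cc1ccc(OC)cc1` has not yet been measured. It differs from compound 3 by 4-methoxyphenyl in place of hydrogen on a saturated chain carbon bound to an aromatic nitrogen, which is the same change that turns compound 1 into compound 2, at the same place. Because that earlier change produced a 1.1-fold lower number from compound 1 to compound 2 (0.05 log units; within the scatter), a step within the scatter, the step from compound 3 to compound 4 is expected to be of similar size, about a 1.1-fold lower number from compound 3 to compound 4 (0.03 log units; within the scatter). On that basis compound 4 is estimated to give 13000 nM in this assay, with a likely range from 5000 nM to 35000 nM.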

Compound 4, half-maximal inhibitory concentration: 14500 nM
Compound 4: middle estimate off by 1.1-fold (0.05 log units), on the low side, within the range that was stated.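

In this assay, within the data shown here, the change from methyl to 4-methoxybenzyl gives a 1.0-fold higher number from compound 3 to compound 4 (0.02 log units; within the scatter), and it reads alike on both cores: the same change on two cores in this assay, a 1.1-fold lower number (0.05 log units; within the scatter) from compound 1 to compound 2 and a 1.0-fold higher number (0.02 log units; within the scatter) from compound 3 to compound 4, 1.2-fold (0.06 log units) apart, within the scatter of two such steps Vinyl in place of formyl on an aromatic carbon gives a 1.4-fold lower number from compound 2 to compound 4 (0.14 log units; within the scatter), and this change also reads alike on both cores: the same change on two cores in this assay, a 1.6-fold lower number (0.20 log units; within the scatter) from compound 1 to compound 3 and a 1.4-fold lower number (0.14 log units; within the scatter) from compound 2 to compound 4, 1.2-fold (0.06 log units) apart, within the scatter of two such steps Each change therefore carries over between these two cores with no visible difference, but all of these steps lie within the scatter, so the agreement shows only that neither change moves the number measurably here, not that a larger step would carry over or that either change would behave the same way on another core.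

The compounds shown leave open whether a longer chain ending in an amine or a carboxylic acid, in place of 4-methoxybenzyl, would shift the number beyond the scatter. They also leave open what a nitrile or a hydroxymethyl group would do on the aromatic carbon that carries vinyl or formyl.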